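Chloro for methyl on the anilide ring of compound 1

This account rests on a few compounds, and the source may have more. Where it says the series, first, only, none or still open, it means among the compounds named here.

Compound 1 `Cc1cccc(Cl)c1NC(=O)/N=C1\CCCN1C` stands only at a limit in a functional assay on the whole organism with Rattus norvegicus as the target, with a stated time of 5 days; on this read-out higher numbers stand for an effect only at larger amounts of compound and lower numbers for an effect already at smaller amounts: compound 1 gives > 25 mg/kg, which is a limit and not a number. Compound 3 `CN1CCC/C1=N\C(=O)Nc1cccc(I)c1` also stops at a limit, giving > 25 mg/kg in this assay. For compound 2 `CCc1cccc(C)c1NC(=O)/N=C1\CCCN1C` this assay records "not determined" (no result reported). Compound 1 therefore rests on (the limit of > 25 mg/kg in this assay, at which 2 of the 3 values shown sit), with no numbered value anywhere in the set.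

Compound 4 `CN1CCC/C1=N\C(=O)Nc1c(Cl)cccc1Cl` differs from compound 1 by chloro in place of methyl on an aromatic carbon. Among the compounds with values here, no step between measured compounds is known, so the size of this change rests on expectation alone. As compound 1 sits at the limit of > 25 mg/kg in this assay, at which 2 of the 3 values shown sit, the step is expected at a step that the limit leaves unreadable from compound 1 to compound 4, no further than the scatter. Compound 4 is estimated at 30 mg/kg, within a range from 10 mg/kg to 100 mg/kg, most likely again reported only as a limit.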

Compound 4, minimum effective dose: > 25 mg/kg
Compound 4 gave a limit, no number (the forecaster's own chance of this, stated with the estimate: 70%); the middle value lies beyond the limit too.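

Within the data shown here, compound 1 and compound 4 both stop at a limit in this assay, so no step between them can be read: the limit of > 25 mg/kg in this assay, at which 3 of the 4 values shown sit. The compounds shown leave open at which dose any of them takes effect.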